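The source may hold more compounds than are shown below. What is called first, only, known or untested is meant among the compounds shown, and "the series" means these compounds.

Compound 1 `Cc1ccc(-c2cn(C/C=C3\OC(=O)C(OCc4ccccc4)=C3OCc3ccccc3)nn2)cc1` stops at a limit of > 100000 nM in a functional assay on A549 cells (Homo sapiens) for antiproliferative activity, read by MTT assay, with a stated time of 72 h; on this read-out lower numbers stand for stronger inhibition and higher numbers for weaker inhibition. Compound 2 `O=C1O/C(=C\Cn2cc(-c3cc(C(F)(F)F)cc(C(F)(F)F)c3)nn2)C(OCc2ccccc2)=C1OCc1ccccc1` likewise gives only a limit, > 100000 nM, in this assay. Going by the values given here, compound 3 `O=C1O[C@H]([C@@H](O)Cn2cc(CNS(=O)(=O)c3ccc(F)cc3)nn2)C(OCc2ccccc2)=C1OCc1ccccc1` is the one member of the set for which this assay returns a number, 22500 nM; the two other values rest at the limit of > 100000 nM in this assay, at which 2 of the 3 values shown sit. Compound 4 `COc1ccc(-c2cn(C[C@H](O)[C@H]3OC(=O)C(OCc4ccccc4)=C3OCc3ccccc3)nn2)cc1` has not yet been measured. It differs from compound 3 in one place: 4-methoxyphenyl in place of (((4-fluorophenyl)sulfonyl)amino)methyl on an aromatic carbon. Among the compounds with values here, no step between measured compounds is given, so the expectation for compound 4 rests on the three values and on this change. Since compound 1 and compound 2 both sit at the limit of > 100000 nM in this assay, at which 2 of the 3 values shown sit, while compound 3 alone gives a number, the step from compound 3 to compound 4 is expected to run towards weaker inhibition by more than the scatter. Compound 4 is therefore estimated at 60000 nM in this assay, with an expected range from 20000 nM to 100000 nM. That estimate means an expected step of a 2.7-fold higher number from compound 3 to compound 4 (0.43 log units; beyond the scatter).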

Compound 4, half-maximal inhibitory concentration: 28300 nM
For compound 4 the middle estimate is 2.1-fold (0.33 log units) above the measured one; the measured number falls inside the stated range.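

At this place on the five-membered aromatic ring with 3 nitrogen, 4-methoxyphenyl in place of (((4-fluorophenyl)sulfonyl)amino)methyl gives, in this assay, a 1.3-fold higher number from compound 3 to compound 4 (0.10 log units; within the scatter). The two groups therefore cannot be told apart in this read-out, even though they differ in size and in what they carry. Compound 4 also shows that a measurable number at this place does not depend on the sulfonyl amino chain of compound 3, since an aryl group attached directly to the ring keeps one.

Going by these compounds, whether an amine or a carboxylic acid at this place would keep a number remains open. Compound 1 and compound 2 each give only a limit, so no step to either can be read: the limit of > 100000 nM in this assay, at which 2 of the 4 values shown sit.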